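Compound 3 and a Flat Cytotoxicity Step

The compounds below may be only part of what the source reports. "The series", "measured", "known", "first", "only" and "open" are said of these compounds alone.

In a functional assay on SH-SY5Y cells (Homo sapiens) for cytotoxicity, read by MTT assay, with a stated time of 72 h (on this read-out higher numbers stand for weaker inhibition and lower numbers for stronger inhibition), compound 1 `[O-][S+](CCCN=C=S)Cc1ccccc1` gives 8890 nM and compound 2 `[O-][S+](CCCCCN=C=S)Cc1ccccc1` gives 7010 nM. For the measured compounds named here, these two numbers lie within the scatter of each other, so compound 2 cannot be told apart from compound 1, the only neighbour it has on this read-out.

Compound 3 `[O-][S+](CCCCCCN=C=S)Cc1ccccc1` has not yet been measured in this assay. Its structure differs from that of compound 2 as follows: a group of 4 heavy atoms (2 carbon, 1 nitrogen, 1 sulfur; no ring) in place of a group of 3 heavy atoms (1 carbon, 1 nitrogen, 1 sulfur; no ring), on a saturated chain carbon, five bonds along the chain from a sulfur.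

Going by the values given here, only one measured step bears on this change, and it is of a similar kind, with a larger group again taking the place of a smaller one on a saturated chain carbon. That step, a 1.3-fold lower number from compound 1 to compound 2 (0.10 log units; within the scatter), is small and stays within the scatter. Among the compounds with values here, a single step is thin evidence, and nothing measured so far shows how the series behaves beyond compound 2. Even so, the size of the step leads to no expectation of a real shift. The expected step is a 1.1-fold lower number from compound 2 to compound 3 (0.03 log units; within the scatter), which is no change beyond the scatter. For compound 3 the estimated value is 6500 nM, with an expected range from 3300 nM to 11500 nM.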

Compound 3, half-maximal inhibitory concentration: 7630 nM
Compound 3: the middle estimate sits 1.2-fold (0.07 log units) below what was measured; the measured number falls inside the stated range.
By their numbers in this assay, from the lowest: compounds 2, 3 and 1 (each within the scatter of the next).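

In this assay, a group of 4 heavy atoms in place of a group of 3 heavy atoms, on a saturated chain carbon, five bonds along the chain from a sulfur, gives a 1.1-fold higher number from compound 2 to compound 3 (0.04 log units; within the scatter), so a second change of this kind also cannot be told apart from no change. For the compounds shown here, the wider replacement, a larger group in place of a group of 3 heavy atoms, on a saturated chain carbon, three bonds along the chain from a sulfur, gives a 1.2-fold lower number from compound 1 to compound 3 (0.07 log units; within the scatter), which shows what the single earlier step could not: the two ends of this three-compound set also lie within the scatter of each other. Nothing at hand bears on why this read-out stays flat across these chains.

From the compounds shown here alone, whether a longer chain than that of compound 3 would still leave the number within the scatter remains open. So does the effect of an amine or a carboxylic acid at this place, since every compound shown carries a group of the same kind there.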